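This account rests on a few compounds, and the source may have more. Where it says the series, first, only, none or still open, it means among the compounds named here.

Compound 1, with the structure `O=C(NN=C(c1ccccn1)c1ccccn1)c1cccc(Br)c1`, is one of three measured members of a small set of hydrazone-type compounds tested for their ability to slow the growth of human cells. In an ADME assay on cells (Homo sapiens) for antiproliferative activity, read by MTT assay (on this read-out lower numbers stand for stronger inhibition and higher numbers for weaker inhibition), compound 1 gives 240 nM. Compound 2, with the structure `O=C(NN=C(c1ccccn1)c1ccccn1)c1ccccc1`, shares the core of compound 1 and differs from it only in one spot: hydrogen in place of bromo on an aromatic carbon. That single change produced a 13-fold higher number from compound 1 to compound 2 (1.10 log units; beyond the scatter), so that in this assay compound 2 gives 3040 nM.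

Compound 3, with the structure `C/C(=N\NC(=O)c1ccc(Br)cc1)c1cnccn1`, is built on a different core. The difference between the two cores is not broken down here. In this assay compound 3 gives 1220 nM.

Compound 4, with the structure `C/C(=N\NC(=O)c1ccccc1)c1cnccn1`, has not yet been measured. It differs from compound 3 in one place: hydrogen in place of bromo on an aromatic carbon. For the measured compounds named here, this is the same kind of change as the one from compound 1 to compound 2, though the surroundings are not identical: in compound 1 the bromo sits meta to a large group, whereas in compound 3 it sits para to a large group. Going by the values given here, because the earlier change gave a 13-fold higher number from compound 1 to compound 2 (1.10 log units; beyond the scatter), a step of similar direction is expected here, and an 8.2-fold higher number from compound 3 to compound 4 (0.91 log units; beyond the scatter) is the size estimated for it, with a wide range to reflect that only one such comparison exists and the cores differ. Compound 4 is therefore expected to give 10000 nM in this assay, with an estimated range from 3000 nM to 35000 nM.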

Compound 4, half-maximal inhibitory concentration in the Homo sapiens assay: 3620 nM
For compound 4 the middle estimate is 2.8-fold (0.44 log units) above the measured one, and the stated range covers the measured number.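

In the Homo sapiens assay, replacing the bromo with hydrogen again gives weaker inhibition, a 3.0-fold higher number from compound 3 to compound 4 (0.47 log units; beyond the scatter), so the direction of the change carries over from the core of compound 1 to the core of compound 3, while its size does not: the same change on two cores in the Homo sapiens assay, a 13-fold higher number (1.10 log units; beyond the scatter) from compound 1 to compound 2 and a 3.0-fold higher number (0.47 log units; beyond the scatter) from compound 3 to compound 4, 4.3-fold (0.63 log units) apart, beyond the scatter of two such steps. In a physicochemical assay for lipophilicity (a higher number here means a more lipophilic compound, a lower number a more polar compound), compound 3 gives 2.9 and compound 4 gives 1.9. The same replacement thus makes compound 4 measurably less lipophilic than compound 3, which runs alongside its weaker inhibition, but this single pair cannot show that the loss of lipophilicity is what weakens the inhibition: the measured partition coefficient of compound 3, 2.9, and of compound 4, 1.9, a number 1.00 log units lower (beyond the scatter). Two pairs are enough to show that the size of this step depends on its surroundings, but they cannot show how large it would be on a further core, nor which part of the two cores sets the gap between the steps.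

The compounds shown leave open whether that gap comes from the cores themselves or from where the bromo sits on the ring, since the two bromo compounds differ in both respects. They also leave open whether a group other than bromo on the same ring, such as chloro, methoxy or an amine, would give inhibition like that of the bromo compounds or that of the hydrogen compounds.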